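This account rests on a few compounds, and the source may have more. Where it says the series, first, only, none or still open, it means among the compounds named here.

In a physicochemical assay for acid dissociation, compound 2 `COc1ccc(F)cc1CNCCCNc1ccnc2cc(Cc3ccc(F)cc3Cl)ccc12` gives 9.47. Compound 1 `CC(C)Cc1ccc2c(NCCCNCc3ccco3)ccnc2c1` gives 9.47 and compound 3 `Fc1ccc(Cc2ccc3c(NCCCNCc4ccco4)ccnc3c2)c(Cl)c1` gives 9.47, so compound 2 stands level with both at the digits shown, within the usual scatter. Compound 4 `COc1ccc(F)cc1CNCCCNc1ccnc2cc(Oc3ccc(Cl)cc3)ccc12` has not yet been measured. It differs from compound 2 at a single place: 4-chlorophenoxy in place of 2-chloro-4-fluorobenzyl on an aromatic carbon. For the measured compounds named here, two measured steps bear on such a change. The step of no change at the digits printed from compound 1 to compound 3 (within the scatter) put 2-chloro-4-fluorophenyl in place of isopropyl on a saturated chain carbon bound to an aromatic carbon, and the value stayed where it was. The step of no change at the digits printed from compound 2 to compound 3 (within the scatter) put furan-2-yl in place of 5-fluoro-2-methoxyphenyl on a saturated chain carbon bound to an amine nitrogen, again without moving the value. Since neither step shifted the number, no step beyond the scatter is expected in this assay for compound 4. The expected step for compound 4 is no change at the digits printed from compound 2 to compound 4 (within the scatter). Compound 4 is therefore estimated at 9.47, between 9.17 and 9.77.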

Compound 4, acid dissociation constant: 9.28
Beside the measured number, compound 4's estimate is 0.19 log units above it; low and high end bracket the measured number.
By their numbers in this assay, from the lowest: compounds 4, 1, 2 and 3 (each within the scatter of the next).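

In this assay, the step of a number 0.19 log units lower from compound 2 to compound 4 (within the scatter) is the first shown at an aromatic carbon itself, on the ring that is meta to a fused ring and para to a fused ring, whereas the earlier steps both fell on saturated chain carbons. It shows that this place accepts an exchange of 2-chloro-4-fluorobenzyl for 4-chlorophenoxy, which brings in an oxygen and a hydrogen-bond acceptor, with a difference that stays within the scatter. No measurement offered here bears on why this is so.

Only these two groups are shown at this aromatic carbon, so the compounds leave open whether an amine, a carboxylic acid or a longer chain there would also stay within the scatter. They also leave open whether the same exchange would give a similar step with the furan-2-yl group of compound 3 in place of 5-fluoro-2-methoxyphenyl.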